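A Small Aromatic Group Exchange in a Cytotoxicity Test

This account rests on a few compounds, and the source may have more. Where it says the series, first, only, none or still open, it means among the compounds named here.

In a toxicity assay on MT4 cells (Homo sapiens) for cytotoxicity, read by MTT assay (on this read-out higher numbers stand for lower toxicity in this test and lower numbers for higher toxicity in this test), compound 1 (`Cc1cc(Oc2cc(N)nc(Nc3ccc(C#N)cc3)n2)ccc1-c1ccc(C#N)cc1`) gives 34300 nM and compound 2 (`Cc1cc(-c2ccccc2F)cc(C)c1Oc1cc(N)nc(Nc2ccc(C#N)cc2)n1`) gives 29300 nM and these two values lie within the usual scatter of each other. Compound 3 (`Cc1cccc(-c2cc(C)c(Oc3cc(N)nc(Nc4ccc(C#N)cc4)n3)c(C)c2)c1`) carries 3-methylphenyl in place of 2-fluorophenyl on an aromatic carbon of compound 2, and the exchange counts as follows: 3-methylphenyl in place of 2-fluorophenyl on an aromatic carbon. Within the data shown here, no measured pair shows this exchange alone, so no step beyond the scatter is expected in this assay here. The estimated change is a 1.1-fold lower number from compound 2 to compound 3 (0.04 log units; within the scatter) and it stays within the scatter. Compound 3 is expected at 27000 nM with 9000 nM to 80000 nM as the estimated range.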

Compound 3, half-maximal cytotoxic concentration: 27600 nM
Estimate against measurement, compound 3: 1.0-fold (0.01 log units) below; low and high end bracket the measured number.
By their numbers in this assay, from the lowest: compounds 3, 2 and 1 (each within the scatter of the next).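

In this assay, putting 3-methylphenyl in place of 2-fluorophenyl gives a 1.1-fold lower number from compound 2 to compound 3 (0.03 log units; within the scatter) and so leaves the two compounds indistinguishable in this test. This first step at the position, meta to two methyl groups and para to a large group, shows that this exchange of one aromatic ring for another does not shift the read-out beyond the scatter. Nothing available here offers an explanation for this result. As far as these compounds go, both groups are six-membered aromatic rings of carbon only, so whether an amine or a carboxylic acid on this carbon would give a different number remains open.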